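Swapping the aryl group on an amide-type nitrogen

The compounds below may be only part of what the source reports. "The series", "measured", "known", "first", "only" and "open" are said of these compounds alone.

Measured compounds:
compound 1 `O=C(O)CCC(=O)OCCCCCCSc1ccc([N+](=O)[O-])c2nonc12` with 530 nM
compound 2 `O=C(CCC(=O)OCCCCCCSc1ccc([N+](=O)[O-])c2nonc12)Nc1ccccc1Cl` with 15500 nM
compound 3 `O=C(CCC(=O)OCCCCCCSc1ccc([N+](=O)[O-])c2nonc12)Nc1cccc(Cl)c1` with 28800 nM

These three were tested in an assay on isolated protein for inhibition of glutathione S-transferase P (Homo sapiens), with a stated time of 10 min; on this read-out lower numbers stand for stronger inhibition and higher numbers for weaker inhibition. Among them compound 2 stands second highest; its nearest neighbour is compound 3, a step that is within the scatter a 1.9-fold higher number from compound 2 to compound 3 (0.27 log units; within the scatter), while compound 1 lies far below it a 29-fold higher number from compound 1 to compound 2 (1.47 log units; beyond the scatter). Compound 4 `Cc1ccc(NC(=O)CCC(=O)OCCCCCCSc2ccc([N+](=O)[O-])c3nonc23)cc1` is the next member and differs from compound 2 by 4-methylphenyl in place of 2-chlorophenyl on an amide-type nitrogen. Within the data shown here, the only step that speaks to such a swap of one aryl group for another on the amide-type nitrogen is a 1.9-fold higher number from compound 2 to compound 3 (0.27 log units; within the scatter), which stayed within the scatter. A change of similar modesty is therefore expected in this assay, with no clear direction. Compound 4 is estimated at 20000 nM, with a plausible range from 7000 nM to 55000 nM, which means an expected step of a 1.3-fold higher number from compound 2 to compound 4 (0.11 log units; within the scatter).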

Compound 4, half-maximal inhibitory concentration: 6800 nM
Compound 4: the middle estimate sits 2.9-fold (0.47 log units) above what was measured; measured number outside the range, below it.
By their numbers in this assay, from the lowest: compound 1; then compound 4; then compounds 2 and 3 (each within the scatter of the next).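

In this assay, the choice of aryl group on the amide-type nitrogen can matter: 4-methylphenyl in place of 2-chlorophenyl gives a 2.3-fold lower number from compound 2 to compound 4 (0.36 log units; beyond the scatter), and in place of 3-chlorophenyl it gives a 4.2-fold lower number from compound 3 to compound 4 (0.63 log units; beyond the scatter). Even so, hydroxy on the carbonyl carbon still gives the lower number, with a 13-fold higher number from compound 1 to compound 4 (1.11 log units; beyond the scatter). Nothing measured here explains these differences.

Going by these compounds, it remains open whether the lower number goes with the methyl group or with where it sits, which 4-chlorophenyl or 3-methylphenyl could separate. Also open, on these data alone, is whether an aryl group carrying an amine or a carboxylic acid would approach compound 1.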